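The source may report more compounds than this note shows. Statements on the series, on what has been measured and on what is new or still open speak of the compounds shown alone.

Compound 1, `Cc1cc2nn(-c3ccccc3)c(N)c2c(=O)[nH]1`, gives 4% in an assay on isolated protein for inhibition of ribosomal protein S6 kinase alpha-5 (Homo sapiens), read by mobility shift assay, tested at 30 uM; a lower number here means less inhibition, a higher number more inhibition at the concentration tested (going by the name of the read-out). Compound 2, `Nc1c2c(=O)[nH]c(-c3ccccc3)cc2nn1-c1ccccc1`, gives 13%. Compound 3, `COc1ccc(-c2cc3nn(-c4ccccc4)c(N)c3c(=O)[nH]2)cc1`, gives 6%.

Compound 3 stands second highest of the three numbers, but the steps of a number 2 percentage points higher from compound 1 to compound 3 (within the scatter) and a number 7 percentage points lower from compound 2 to compound 3 (within the scatter) both lie within the scatter, so no order among the three can be read from them. Compound 4, `CN1CCN(c2ccc(-c3cc4nn(-c5ccccc5)c(N)c4c(=O)[nH]3)cc2)CC1`, differs from compound 3 by 4-methylpiperazin-1-yl in place of methoxy on an aromatic carbon. Going by the values given here, the step that bears most directly on this change is a number 7 percentage points lower from compound 2 to compound 3 (within the scatter), the only earlier change at that place, and it stayed within the scatter; the steps of a number 9 percentage points higher from compound 1 to compound 2 (within the scatter) and a number 2 percentage points higher from compound 1 to compound 3 (within the scatter) did likewise. No step beyond the scatter is therefore expected in this assay. Compound 4 is estimated at 8%, within 0% to 20%. The expected step is a number 2 percentage points higher from compound 3 to compound 4 (within the scatter).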

Compound 4, a percentage reported as inhibition, at one concentration (the size of the read-out at that concentration, not a potency): 12%
Estimate against measurement, compound 4: 4 percentage points below; the range from low to high includes it.
By their numbers in this assay, from the lowest: compounds 1, 3, 4 and 2 (each within the scatter of the next).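

Even a group as large as 4-methylpiperazin-1-yl, with its six-membered non-aromatic ring, leaves this assay without a readable change: replacing methoxy gives a number 6 percentage points higher from compound 3 to compound 4 (within the scatter), and the comparison with hydrogen at the same place gives a number 1 percentage points lower from compound 2 to compound 4 (within the scatter). Hydrogen, methoxy and 4-methylpiperazin-1-yl therefore cannot be told apart at this place on the evidence of compound 2, compound 3 and compound 4. Nothing available accounts for these numbers. From the compounds shown here alone, whether a carboxylic acid or a primary amine at this place would produce a step beyond the scatter remains open.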